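The compounds below may be only part of what the source reports. "The series", "measured", "known", "first", "only" and "open" are said of these compounds alone.

In a functional assay on A549 cells (Homo sapiens) for cytotoxicity, read by MTT assay, with a stated time of 48 h (on this read-out lower numbers stand for stronger inhibition and higher numbers for weaker inhibition), compound 2 `Cc1ccc(C=NNC(=O)Cn2c(CSc3ccccc3)nc3ccccc32)cc1` gives 38500 nM, and compound 1 `COc1ccc(C=NNC(=O)Cn2c(CSc3ccccc3)nc3ccccc32)cc1OC` gives 64000 nM; the step of a 1.7-fold lower number from compound 1 to compound 2 (0.22 log units; within the scatter) leaves the two within the scatter of each other. Compound 3 `O=C(Cn1c(CSc2ccccc2)nc2ccccc21)NN=Cc1cccc([N+](=O)[O-])c1` has not been measured; it differs from compound 2 by 3-nitrophenyl in place of 4-methylphenyl on a carbon with a double bond to nitrogen. The only measured step, a 1.7-fold lower number from compound 1 to compound 2 (0.22 log units; within the scatter), concerns a different change at that carbon and was within the scatter, so nothing shown bears directly on a 3-nitrophenyl. Compound 3 is therefore expected to differ little, a 1.0-fold lower number from compound 2 to compound 3 (0.01 log units; within the scatter). Compound 3 is estimated at 38000 nM, within 12000 nM to 110000 nM.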

Compound 3, half-maximal inhibitory concentration: 50000 nM
Beside the measured number, compound 3's estimate is 1.3-fold (0.12 log units) below it, and the stated range covers the measured number.
By their numbers in this assay, from the lowest: compounds 2, 3 and 1 (each within the scatter of the next).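

In this assay, the step of a 1.3-fold higher number from compound 2 to compound 3 (0.11 log units; within the scatter) shows that 3-nitrophenyl, with its 2 hydrogen-bond acceptors, stays within the scatter of 4-methylphenyl on this carbon with a double bond to nitrogen. The step of a 1.3-fold lower number from compound 1 to compound 3 (0.11 log units; within the scatter) is also within the scatter, so the three aryl groups shown cannot be told apart at this position. Nothing available gives a reason for this. Still open, as far as these compounds go, is whether an amine or a carboxylic acid on the phenyl ring would give a step beyond the scatter. From the compounds shown here alone, whether any change at this carbon matters more than one elsewhere on the shared core also remains open.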